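Ring-ester replacements for the side-chain ether

The source may hold more compounds than are shown below. What is called first, only, known or untested is meant among the compounds shown, and "the series" means these compounds.

Measured so far:
compound 1 `COCCO[C@H](CC=C(C)C)C1=CC(=O)c2c(O)ccc(O)c2C1=O` gives 43200 nM in a functional assay on DU-145 cells (Homo sapiens) for cytotoxicity, read by MTT assay; on this read-out lower numbers stand for stronger inhibition and higher numbers for weaker inhibition
compound 2 `CCC(CO[C@H](CC=C(C)C)C1=CC(=O)c2c(O)ccc(O)c2C1=O)OC(C)=O` gives 25400 nM in this assay
compound 3 `CC(C)=CC[C@@H](OC(=O)C1CCCO1)C1=CC(=O)c2c(O)ccc(O)c2C1=O` gives 10500 nM in this assay

Compound 1 stands highest of the three numbers; the gap to compound 2 is a 1.7-fold lower number from compound 1 to compound 2 (0.23 log units; within the scatter), and the gap to compound 3 is a 4.1-fold lower number from compound 1 to compound 3 (0.61 log units; beyond the scatter). Compound 4 `CC(C)=CC[C@@H](OC(=O)C1CCCCO1)C1=CC(=O)c2c(O)ccc(O)c2C1=O` carries the change ((oxan-2-yl)carbonyl in place of 2-methoxyethyl on an oxygen on a saturated carbon). Going by the values given here, the only measured step on the same oxygen that exchanges the 2-methoxyethyl for a ring-bearing carbonyl is a 4.1-fold lower number from compound 1 to compound 3 (0.61 log units; beyond the scatter), a five-membered ring where compound 4 carries a six-membered one. A step of similar size and direction is expected, a 3.9-fold lower number from compound 1 to compound 4 (0.59 log units; beyond the scatter). Compound 4 is therefore estimated at 11000 nM, with a range from 4000 nM to 30000 nM.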

Compound 4, half-maximal inhibitory concentration: 24700 nM
For compound 4 the middle estimate is 2.2-fold (0.35 log units) below the measured one; the measured number falls inside the stated range.
By their numbers in this assay, from the lowest: compound 3; then compounds 4, 2 and 1 (each within the scatter of the next).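

In this assay the ring size on the carbonyl counts: a 2.4-fold higher number from compound 3 to compound 4 (0.37 log units; beyond the scatter) comes with oxan-2-yl in place of oxolan-2-yl, so the modest gain of the five-membered ester does not carry over to the six-membered one. The 2-methoxyethyl and 2-acetoxybutyl ethers are not separated from this ester, with a 1.7-fold lower number from compound 1 to compound 4 (0.24 log units; within the scatter) and a 1.0-fold lower number from compound 2 to compound 4 (0.01 log units; within the scatter) both within the scatter. Nothing at hand accounts for the ring-size step. Open, as far as these compounds go, is whether an open-chain acetyl group or a pyrrolidine-bearing carbonyl on the same oxygen would track the five-membered or the six-membered ester.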